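Swapping the Nitrophenyl Arm for a Benzothiophene

The source may report more compounds than this note shows. Statements on the series, on what has been measured and on what is new or still open speak of the compounds shown alone.

Three analogues of a shared core have been tested in a functional assay on Jurkat cells for inhibition of nuclear factor NF-kappa-B complex (Homo sapiens); on this read-out higher numbers stand for weaker inhibition and lower numbers for stronger inhibition. Compound 1 `CCOC(=O)c1cnc(SC)nc1NN1C(=O)C=C(C)C1=O` gives 200 nM. Compound 2 `CCOC(=O)c1cnc(-c2ccc(OC)cc2)nc1NN1C(=O)C=C(C)C1=O`, which carries a 4-methoxyphenyl group in place of the methylsulfanyl group, gives 900 nM, and compound 3 `CCOC(=O)c1cnc(-c2cccc([N+](=O)[O-])c2)nc1NN1C(=O)C=C(C)C1=O`, which carries a 3-nitrophenyl group in place of the methylsulfanyl group, gives 7000 nM. Compound 3 thus stands at the highest number of the three: the step of a 35-fold higher number from compound 1 to compound 3 (1.54 log units; beyond the scatter) was large, and the step of a 7.8-fold higher number from compound 2 to compound 3 (0.89 log units; beyond the scatter) was modest.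

Compound 4 `CCOC(=O)c1cnc(-c2cc3ccccc3s2)nc1NN1C(=O)C=C(C)C1=O` has not yet been measured. It differs from compound 3 in one place: 1-benzothiophen-2-yl in place of 3-nitrophenyl on an aromatic carbon. The measured steps that bear on this change are those in which the group at this position was exchanged: a 4.5-fold higher number from compound 1 to compound 2 (0.65 log units; beyond the scatter), a 35-fold higher number from compound 1 to compound 3 (1.54 log units; beyond the scatter) and a 7.8-fold higher number from compound 2 to compound 3 (0.89 log units; beyond the scatter). Both aromatic groups tried so far gave weaker inhibition than methylsulfanyl, and the 3-nitrophenyl group the weakest of all, so outcomes at this position have spread widely. Since the group that leaves is the one tied to the highest number, compound 4 is expected to show a step of a 3.5-fold lower number from compound 3 to compound 4 (0.54 log units; beyond the scatter), back toward the number of compound 2. Compound 4 is therefore estimated at 2000 nM, with a likely range from 500 nM to 8000 nM.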

Compound 4, half-maximal inhibitory concentration: 4000 nM
Compound 4: the middle estimate sits 2.0-fold (0.30 log units) below what was measured; the measured number falls inside the stated range.
By their numbers in this assay, from the lowest: compound 1; then compound 2; then compounds 4 and 3 (each within the scatter of the next).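

In this assay, replacing 3-nitrophenyl with 1-benzothiophen-2-yl gives a step that cannot be told from repeat-measurement noise (a 1.8-fold lower number from compound 3 to compound 4 (0.24 log units; within the scatter)), so here losing the nitro group and gaining a second aromatic ring leave the read-out essentially unmoved. The other two comparisons are clearer (a 4.4-fold higher number from compound 2 to compound 4 (0.65 log units; beyond the scatter); a 20-fold higher number from compound 1 to compound 4 (1.30 log units; beyond the scatter)), and they add a third aromatic group to the pattern at this position: compounds 2, 3 and 4 all inhibit more weakly than compound 1 with its methylsulfanyl group, and none of the four compounds goes against this. Nothing measured alongside these numbers explains the gaps between these groups.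

On these data alone, compound 4 carries sulfur too, but inside an aromatic ring, so it remains open whether the stronger inhibition of compound 1 depends on a sulfur atom attached directly to the core, and a methoxy group, an amine or a longer chain such as ethylsulfanyl at the same position would help separate these possibilities. As far as these compounds go, it is also open how an unsubstituted phenyl group would compare with the 4-methoxyphenyl and 3-nitrophenyl groups.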